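The source may report more compounds than this note shows. Statements on the series, on what has been measured and on what is new or still open speak of the compounds shown alone.

Measured in a functional assay on A549 cells (Homo sapiens) for cytotoxicity, with a stated time of 48 h (on this read-out lower numbers stand for stronger inhibition and higher numbers for weaker inhibition), so far:
- compound 1 `CCCCCOc1ccc2oc(/C=C/[S+](C)[O-])cc(=O)c2c1` gives 1600 nM in this series
- compound 2 `C[S+]([O-])/C=C/c1cc(=O)c2cc(C#N)ccc2o1` gives > 10000 nM as a limit, not a number

Compound 2 has no number, only the limit > 10000 nM of the assay, and the limit of > 10000 nM in this assay, at which 1 of the 2 values shown sits, in these notes.

Compound 3 `CCC(=O)Oc1ccc2oc(/C=C/[S+](C)[O-])cc(=O)c2c1` carries propanoyloxy in place of cyano on an aromatic carbon and is not yet measured. For the measured compounds named here, the one measured step that bears on this change is an at least 6.2-fold higher number from compound 1 to compound 2 (0.79 log units; beyond the scatter) and it swaps pentyloxy for cyano. Read in reverse, it points to a lower number once cyano leaves. Propanoyloxy is not pentyloxy, however, so only part of that return to the level of compound 1 at 1600 nM is expected in this assay here.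

The expected move is an at least 2.0-fold lower number from compound 2 to compound 3 (0.30 log units; that floor lies within the scatter) (an estimate, towards lower numbers).

Compound 3 is estimated at 5000 nM (expected range 1500 nM to 15000 nM).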

Compound 3, half-maximal inhibitory concentration: 2400 nM
Estimate against measurement, compound 3: 2.1-fold (0.32 log units) above; the range from low to high includes it.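

In this assay, propanoyloxy in place of cyano gives an at least 4.1-fold lower number from compound 2 to compound 3 (0.61 log units; beyond the scatter), so at this aromatic carbon a measurable value does not depend on pentyloxy alone: two different groups attached through oxygen both give one. Propanoyl in place of pentyl on that oxygen gives a 1.5-fold higher number from compound 1 to compound 3 (0.18 log units; within the scatter), so these two groups cannot be told apart in this assay, and the chain on the oxygen tolerates this change. Compound 2 is held only by a limit of the assay, not a number: the limit of > 10000 nM in this assay, at which 1 of the 3 values shown sits.

On these data alone, it remains open whether the oxygen attachment itself matters or whether other groups at this carbon would serve equally well, such as an amine or a simple hydroxyl group. As far as these compounds go, it is also open how a longer chain on the oxygen would read in this assay.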